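Aryl urea series: replacing the methylpiperazine with pyridin-2-yl

A few compounds are considered here, and "the series" means these few. Any claim that something is new, unique, unknown or untested is made for them only; others in the source may bear on it.

Working notes on three measured ureas and one untested analogue. In an assay on microsomes from intestine for inhibition of acyl-CoA:cholesterol acyltransferase (Oryctolagus cuniculus) (a lower number here means a stronger inhibitor, a higher number a weaker inhibitor), compound 1 `Cc1cc(C)c(NC(=O)N(Cc2cc(-c3ccccc3)on2)C2CCCCCC2)c(C)c1` gives 61 nM. In this assay compound 2 `Cc1cc(C)c(NC(=O)N(Cc2ccc(N3CCN(C)CC3)cc2)C2CCCCCC2)c(C)c1` gives 57 nM, the second highest of the three numbers; compound 1 is nearest and within the scatter, compound 3 `CN(C)c1ccc(CN(Cc2cccc(-c3cc[nH]n3)c2)C(=O)Nc2c(F)cc(F)cc2F)cc1` is furthest with 12 nM, beyond the scatter and lower. Compound 4 `Cc1cc(C)c(NC(=O)N(Cc2ccc(-c3ccccn3)cc2)C2CCCCCC2)c(C)c1` differs from compound 2 by pyridin-2-yl in place of 4-methylpiperazin-1-yl on an aromatic carbon. Among the measured compounds shown here, no step between measured compounds covers this exchange, and compound 1 shows that an aromatic substituent at the benzyl side is tolerated. Compound 4 is therefore expected to show no step beyond the scatter in this assay, with a 1.1-fold higher number from compound 2 to compound 4 (0.02 log units; within the scatter) as the estimated change. The estimate for compound 4 is 60 nM, within a range from 25 nM to 150 nM.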

Compound 4, half-maximal inhibitory concentration: 33 nM
Compound 4: the middle estimate sits 1.8-fold (0.26 log units) above what was measured; low and high end bracket the measured number.
By their numbers in this assay, from the lowest: compound 3; then compounds 4, 2 and 1 (each within the scatter of the next).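

In this assay, among the compounds shown here, the exchange of 4-methylpiperazin-1-yl for pyridin-2-yl gives a 1.7-fold lower number from compound 2 to compound 4 (0.24 log units; within the scatter) on this aromatic carbon, the first direct reading at this position. The assay therefore does not separate the six-membered non-aromatic ring from the six-membered aromatic ring at this place. Nothing available bears on the reason for this result. Still open, as far as these compounds go, is whether a carboxylic acid, a primary amine or a morpholin-4-yl group at this carbon would stay within the scatter of compound 2, and whether pyridin-3-yl would read like pyridin-2-yl.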